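Alkyne-thiazole series: amide to urea change at the ring nitrogen

The source may hold more compounds than are shown below. What is called first, only, known or untested is meant among the compounds shown, and "the series" means these compounds.

Measured so far:
compound 1, `O=C1NCCc2nc(C#Cc3cccc(F)c3)sc21`, 290 nM
compound 2, `O=C(C1CC(F)C1)N1CCc2nc(C#Cc3ccccc3)sc2C1`, 85 nM
compound 3, `O=S(=O)(N1CCCCC1)N1Cc2nc(C#Cc3ccccc3)sc2C1`, 250 nM

All three numbers come from an assay on HEK293 cells for positive allosteric modulation of metabotropic glutamate receptor 5 (Homo sapiens), read by FLIPR, with a stated time of 1 h; a lower number here means that less compound is needed, a higher number that more compound is needed for the effect. Compound 2 stands lowest of the three; compound 3 is nearest, and compound 1 furthest, both gaps lying beyond the scatter. Compound 4, `O=C(N1CCCCC1)N1CCc2nc(C#Cc3ccccc3)sc2C1`, is not yet measured. It differs from compound 2 in one place: piperidin-1-yl in place of 3-fluorocyclobutyl on a carbonyl carbon. Nothing measured here isolates this change, since compound 3 carries its piperidin-1-yl on a sulfonyl group and on a different core, so its value can only hint at where a piperidine-bearing analogue may land. A modest rise in the number is expected, because compound 3 gives 250 nM against compound 2 at 85 nM, and the step itself is estimated at a 1.9-fold higher number from compound 2 to compound 4 (0.27 log units; within the scatter). For compound 4 in this assay the expected value is 160 nM, with a range from 60 nM to 450 nM.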

Compound 4, half-maximal effective concentration: 75 nM
The estimate for compound 4 lay 2.1-fold (0.33 log units) above the measured number; measured number inside the range.
By their numbers in this assay, from the lowest: compounds 4 and 2 (each within the scatter of the next); then compounds 3 and 1 (each within the scatter of the next).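

In this assay, among these compounds, piperidin-1-yl in place of 3-fluorocyclobutyl on a carbonyl carbon gives a 1.1-fold lower number from compound 2 to compound 4 (0.05 log units; within the scatter), the first comparison that differs in only one place. At this position, the amide of compound 2 and the urea of compound 4 are therefore not separated, and the fluorine-bearing four-membered ring is not required to stay at this level of this assay. No supporting measurement is available to explain this result.

Still open, from the compounds shown here alone, is whether other groups on this carbonyl carbon, such as morpholin-4-yl or an open-chain diethylamino group, would also stay at this level. The effect of a sulfonyl group in place of the carbonyl also remains unresolved, since compound 3 differs from compound 4 in more than one place.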